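The source may hold more compounds than are shown below. What is called first, only, known or untested is meant among the compounds shown, and "the series" means these compounds.

Working notes on the series. Compound 3 `CCOC(=O)C1=C(S[C@@H]2CN[C@H](C(=O)Nc3cccc(C(=O)OCC)c3)C2)[C@H](C)[C@@H]2[C@@H]([C@@H](C)O)C(=O)N12` and compound 2 `CCOC(=O)C1=C(S[C@@H]2CN[C@H](C(=O)Nc3cccc(C(=O)OCC)c3)C2)[C@H](C)[C@@H]2[C@@H]([C@@H](C)OC(C)=O)C(=O)N12` share one core; compound 1 `C[C@@H](O)[C@H]1C(=O)N2C3=C(S[C@@H]4CN[C@@H](C4)C(=O)Nc4cccc(c4)C(=O)OCOCOC3=O)[C@H](C)[C@H]12` and compound 4 `CC(=O)O[C@H](C)[C@H]1C(=O)N2C3=C(S[C@@H]4CN[C@@H](C4)C(=O)Nc4cccc(c4)C(=O)OCOCOC3=O)[C@H](C)[C@H]12` share another. The difference between the two cores is not broken down here. In an ADME assay on a cell-free system (plasma, Rattus norvegicus) for metabolic stability, read by LC-MS, with a stated time of 60 min, at 37 degrees C, tested at 50 uM (on this read-out lower numbers stand for a less stable compound and higher numbers for a more stable compound), compound 3 gives 0%. In this assay compound 2 gives 0%, and compound 1 gives 0%. Compound 1 thus stands level with compounds 2 and 3 at the digits read, within the scatter.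

The change from compound 3 to compound 2 is acetyl in place of hydrogen on an oxygen on a saturated carbon, and its step in this assay is no change at the digits printed from compound 3 to compound 2 (within the scatter). The change from compound 1 to compound 4 is acetyl in place of hydrogen on an oxygen on a saturated carbon. Its place reads the same word for word, so this is the same change, hydroxy to acetoxy, made a second time on the other core.

Within the data shown here, the only measured instance of the change, no change at the digits printed from compound 3 to compound 2 (within the scatter), left the read-out where it stood, and compound 1 already reads 0%. The step from compound 1 to compound 4 in this assay is therefore expected to be no change at the digits printed from compound 1 to compound 4 (within the scatter). Compound 4 is estimated at 0%, expected between 0% and 8%.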

Compound 4, percent of the compound remaining in the plasma assay: 0%
Compound 4: the middle estimate sits on the measured number at the digits printed, within the range that was stated.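

In the plasma assay, hydroxy to acetoxy gives no change at the digits printed from compound 1 to compound 4 (within the scatter), so on the two cores shown the change carries over without a difference between its steps: the same change on two cores in the plasma assay, no change at the digits printed (within the scatter) from compound 3 to compound 2 and no change at the digits printed (within the scatter) from compound 1 to compound 4, 0 percentage points apart, within the scatter of two such steps This does not show that the change would have the same size wherever it is made, since both steps start and end at the bottom of the read-out, where any further loss cannot appear, and the match therefore says nothing about a compound with a measurable remainder. In a physicochemical assay for metabolic stability, read by LC-MS, in phosphate buffer, with a stated time of 3 h, at pH 7.4, tested at 50 uM (on this read-out lower numbers stand for a less stable compound and higher numbers for a more stable compound), the step cannot be read, and the values there are limits of the assay, not numbers: the limit of > 95% in the physicochemical assay, at which 2 of the 2 values shown sit. In the physicochemical assay compound 1 gives > 95%, which is a limit of the assay. In the physicochemical assay compound 4 gives > 95%, which is also a limit of the assay.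

Still open, going by these compounds, is whether a longer acyl chain such as butanoyl, or an amine in place of the hydroxy, would lift the reading from the bottom of the read-out on either core. Also open, on these data alone, is how hydroxy to acetoxy reads on a core that leaves some compound remaining, where a step of real size could show.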